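Epimer of Compound 1 in a Cell Permeability Assay

The source may report more compounds than this note shows. Statements on the series, on what has been measured and on what is new or still open speak of the compounds shown alone.

Compound 1 `CC(C)[C@@H](C[C@H]1SC(=O)NC1=O)c1ccc(-c2ccc3cccc(F)c3c2)[nH]c1=O` was tested in an ADME assay on MDCK cells (Canis lupus familiaris) for permeability, in the apical to basolateral direction (a lower number here means that the compound crosses the layer more slowly, a higher number that the compound crosses the layer faster), where compound 1 gives 25.5 10^-6 cm/s. Among the measured compounds shown here, the only other measured compound, compound 2 `CC(C)/C(=C1/SC(=O)NC1=O)c1ccc(-c2ccc3cccc(F)c3c2)[nH]c1=O`, gives 22.9 10^-6 cm/s in this assay; these two numbers lie within the scatter of each other, so compound 1 stands level with compound 2. Compound 3 `CC(C)[C@H](C[C@H]1SC(=O)NC1=O)c1ccc(-c2ccc3cccc(F)c3c2)[nH]c1=O` has not yet been measured. It differs from compound 1 as follows: the two compounds have the same atoms and bonds and differ only in configuration as drawn: 1 of 2 stereo elements differ; a stereocentre at a saturated chain carbon is drawn R in compound 1 and S in compound 3 Across this change the step of a 1.1-fold lower number from compound 1 to compound 3 (0.03 log units; within the scatter) is expected to stay within the scatter, in no particular direction. Compound 3 is therefore estimated to give 24 10^-6 cm/s in this assay, with a range from 13 10^-6 cm/s to 45 10^-6 cm/s.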

Compound 3, apparent permeability: 17.6 10^-6 cm/s
Estimate against measurement, compound 3: 1.4-fold (0.13 log units) above; the range from low to high includes it.
By their numbers in this assay, from the lowest: compounds 3, 2 and 1 (each within the scatter of the next).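

Turning the stereocentre at the saturated chain carbon from R to S gives, in this assay, a 1.4-fold lower number from compound 1 to compound 3 (0.16 log units; within the scatter) on an otherwise identical structure. The configuration at this centre therefore leaves the read-out within the scatter, something compound 2 could not show. The comparison speaks for this centre alone: the fact that compounds 1 and 3 differ only in the configuration as drawn.

The second stereo element has not been seen inverted among these compounds, so its configuration remains an open question. Also open, going by these compounds, is whether this centre stays as silent with an amine or a carboxylic acid on the shared core.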